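The compounds below may be only part of what the source reports. "The series", "measured", "known", "first", "only" and "open" are said of these compounds alone.

Two compounds have been measured in a physicochemical assay for lipophilicity, at pH 7.4; on this read-out lower numbers stand for lower lipophilicity and higher numbers for higher lipophilicity:
compound 1, `CC(C)CN(c1ccc(N(C)C)cc1)S(=O)(=O)c1ccc2c(c1)C(O)CC(C1CCOCC1)O2`, giving 3.51;
compound 2, `CCc1ccc(N(CC2CCC2)S(=O)(=O)c2ccc3c(c2)C(O)CC(C2CCOCC2)O3)cc1`, giving 4.01.

Compound 2 stands highest of these two numbers; compound 1 comes nearest, with a value lower by an amount beyond the usual scatter. Compound 3, `CCc1ccc(N(C2COC2)S(=O)(=O)c2ccc3c(c2)C(O)CC(C2CCOCC2)O3)cc1`, has not yet been measured. It differs from compound 2 in one place: oxetan-3-yl in place of cyclobutylmethyl on a sulfonamide nitrogen. A downward step of a number 1.71 log units lower from compound 2 to compound 3 (beyond the scatter) is expected, larger than the usual scatter. The estimate for compound 3 in this assay is 2.3, most likely between 1.8 and 2.8.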

Compound 3, distribution coefficient: 2.63
Estimate against measurement, compound 3: 0.33 log units below; the measured number falls inside the stated range.
By their numbers in this assay, from the lowest: compound 3; then compound 1; then compound 2.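

In this assay, oxetan-3-yl in place of cyclobutylmethyl on a sulfonamide nitrogen gives a number 1.38 log units lower from compound 2 to compound 3 (beyond the scatter). Going by these compounds alone, this is the first comparison in which only this group changes, and the large step shows that the read-out responds strongly to the group at this position. No measurement shown here accounts for the size of the step. One step cannot separate the effect of the ring oxygen from that of the other differences between the two groups. Also open, going by these compounds, is how cyclobutyl or an amine such as azetidin-3-yl would read on this nitrogen.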